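A few compounds are considered here, and "the series" means these few. Any claim that something is new, unique, unknown or untested is made for them only; others in the source may bear on it.

Measured in a physicochemical assay for solubility, in phosphate buffer, at pH 7.4; on this read-out higher numbers stand for higher solubility and lower numbers for lower solubility:

- compound 1 `CCOC(=O)c1c(-c2cccc(F)c2)[nH]c2cc(OC)ccc2c1=O` gives > 100000 nM (a limit)
- compound 2 `CCOC(=O)c1c(-c2ccc(Cl)cc2)[nH]c2cccc(OC)c2c1=O` gives > 100000 nM (a limit)
- compound 3 `CCOC(=O)c1c(-c2ccccc2Cl)[nH]c2cccc(OC)c2c1=O` gives > 100000 nM (a limit)

Compound 1 has a limit and no number, and it shares that position with the others: the limit of > 100000 nM in this assay, at which 3 of the 3 values shown sit. The step to compound 4 `CCOC(=O)c1c(-c2cccc(C(F)(F)F)c2)[nH]c2cc(OC)ccc2c1=O` puts trifluoromethyl in place of fluoro on an aromatic carbon, (trifluoromethyl in place of fluoro on an aromatic carbon), and leaves the rest of the structure unchanged. For the measured compounds named here, only one measured step bears on it, a step that the two limits leave unreadable from compound 2 to compound 3, and no size can be carried over from it. No step beyond the scatter is therefore expected in this assay, in either direction, and the estimate is a number no higher from compound 1 to compound 4 (the limit leaves the size open) as the expected change. The estimate for compound 4 is 100000 nM in a range from 40000 nM to 200000 nM and a report of only a limit is expected as the likeliest outcome.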

Compound 4, solubility: 19000 nM
The estimate for compound 4 lay 5.3-fold (0.72 log units) above the measured number; measured number outside the range, below it.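

In this assay, trifluoromethyl in place of fluoro, meta to a large group, gives an at least 5.2-fold lower number from compound 1 to compound 4 (0.72 log units; beyond the scatter). For the compounds shown here, this is the first readable step and shows that the read-out at this position can respond to a change of substituent. The step between the chlorophenyl compounds cannot be read, and the earlier compounds showed no such response: the limit of > 100000 nM in this assay, at which 3 of the 4 values shown sit.

As far as these compounds go, whether a methyl group, a methoxy group or an amine at the same place would give a number or a limit remains open. So does whether trifluoromethyl would lower the number on the core of compound 2.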